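Ether variation on a shared benzophenone acid core

The source may hold more compounds than are shown below. What is called first, only, known or untested is meant among the compounds shown, and "the series" means these compounds.

Measured so far:
compound 1, `O=C(O)c1ccc(C(=O)c2ccc(Oc3ccccc3)cc2)cc1`, 33%
compound 2, `O=C(O)c1ccc(C(=O)c2ccc(OC(c3ccccc3)c3ccccc3)cc2)cc1`, 71%

In an assay for displacement of a labelled ligand from 3-oxo-5-alpha-steroid 4-dehydrogenase 2 (Rattus norvegicus), at pH 5.5, tested at 10 uM (on this read-out higher numbers stand for more inhibition at the one concentration tested (going by the name of the read-out) and lower numbers for less inhibition), compound 1 gives 33%. In this assay compound 2 gives 71%. Compound 2 stands highest of the two numbers; its nearest neighbour is compound 1, which lies lower by a gap beyond the usual scatter, so the order of the two is secure.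

Compound 3, `O=C(O)c1ccc(C(=O)c2ccc(OCc3ccccc3)cc2)cc1`, is the next member to be measured in this assay. It is derived from compound 2 by one change: hydrogen in place of phenyl on a saturated chain carbon bound to an aromatic carbon and an oxygen on an aromatic ring. For the measured compounds named here, no step of this kind is available between measured compounds; the two values so far show only that compound 2 sits above compound 1 in this assay.

Since compound 3 is cut back from compound 2 toward the shape of compound 1, a step from compound 2 downward is expected, of size a number 21 percentage points lower from compound 2 to compound 3 (beyond the scatter), probably beyond the scatter. For compound 3 the estimated reading in this assay is 50%, with a range from 30% to 70%.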

Compound 3, a percentage reported as inhibition, at one concentration (the size of the read-out at that concentration, not a potency): 45%
Compound 3: the middle estimate sits 5 percentage points above what was measured; the measured number falls inside the stated range.
By their numbers in this assay, from the lowest: compound 1; then compound 3; then compound 2.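

In this assay, the saturated chain carbon bound to an aromatic carbon and an oxygen on an aromatic ring now shows itself as a place that responds to a single change: hydrogen in place of phenyl there goes with a number 26 percentage points lower from compound 2 to compound 3 (beyond the scatter), so the reading of compound 2 depends on that second phenyl and not only on the ether link to the shared core. Benzyl in place of phenyl on the oxygen on an aromatic ring also registers, with a number 12 percentage points higher from compound 1 to compound 3 (beyond the scatter), which places compound 3 one change away from each of the other two compounds, with a step on either side of it. Nothing measured here gives a reason for either step.

Going by these compounds, whether a methyl or a cyclohexyl on that saturated chain carbon would read closer to compound 3 or to compound 2 remains open, and so does whether the phenyl there can be replaced by anything other than another aromatic ring. On these data alone, it is equally open whether a longer chain between the oxygen and the phenyl would extend the step seen on going from phenyl to benzyl.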